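The source may hold more compounds than are shown below. What is called first, only, known or untested is meant among the compounds shown, and "the series" means these compounds.

Compound 1 `CCS[C@@H]1[C@H](SCC)[C@@H](Cn2cc(-c3ccccc3)nn2)O[C@H]1n1ccc(=O)[nH]c1=O` gives 3040 nM in a functional assay on A549 cells (Homo sapiens) for cytotoxicity, read by MTT assay, with a stated time of 72 h; a higher number here means that more compound is needed for the effect, a lower number that less compound is needed. Compound 2 `CCS[C@@H]1[C@H](SCC)[C@@H](Cn2cc(-c3ccc(F)cc3)nn2)O[C@H]1n1ccc(=O)[nH]c1=O` gives 22900 nM in this assay, a change of a 7.5-fold higher number from compound 1 to compound 2 (0.88 log units; beyond the scatter). Compound 3 `CCS[C@@H]1[C@H](SCC)[C@@H](Cn2cc(-c3ccc(F)cc3)nn2)O[C@H]1n1cc(C)c(=O)[nH]c1=O` is reported only as a limit of this assay, >= 100000 nM, so that compound 3 stands at the weak end of the three shown. The further step, an at least 4.3-fold higher number from compound 2 to compound 3 (0.64 log units; beyond the scatter), is therefore known only as a bound, as the limit of >= 100000 nM in this assay, at which 1 of the 3 values shown sits, tells. Compound 4 `CCS[C@@H]1[C@H](SCC)[C@@H](Cn2cc(-c3cccs3)nn2)O[C@H]1n1cc(C)c(=O)[nH]c1=O` differs from compound 3 by thiophen-2-yl in place of 4-fluorophenyl on an aromatic carbon. Within the data shown here, no measured step touches this ring, so no direction is supported; the nearest comparison is the weakening seen from compound 1 to compound 2. Compound 4 is expected to sit near 60000 nM, between 10000 nM and 150000 nM, an estimated step of an at least 1.6-fold lower number from compound 3 to compound 4 (0.22 log units; that floor lies within the scatter).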

Compound 4, half-maximal effective concentration: 37300 nM
Estimate against measurement, compound 4: 1.6-fold (0.21 log units) above, and the stated range covers the measured number.
By their numbers in this assay, from the lowest: compound 1; then compounds 2 and 4 (each within the scatter of the next). At a limit, above all of these: compound 3.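

Until now this position had changed only by a fluoro on the phenyl ring, whereas here the whole aromatic group on the five-membered aromatic ring with 3 nitrogen is exchanged. In this assay this gives an at least 2.6-fold lower number from compound 3 to compound 4 (0.42 log units; beyond the scatter), so the ring at this position can move the number even with the methyl present on the core. The size of that step is only a bound because one end of it is a limit: the limit of >= 100000 nM in this assay, at which 1 of the 4 values shown sits.

The compounds shown do not tell how thiophen-2-yl reads on the core of compound 1, without that methyl. Going by these compounds, how an amine or a carboxylic acid on this aromatic ring would read also remains open.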